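Thiazolyl in Place of Pyridinyl on the Diaryl Carbon

The source may report more compounds than this note shows. Statements on the series, on what has been measured and on what is new or still open speak of the compounds shown alone.

Compound 2 `N=C(NCCCc1c[nH]cn1)NC(=O)CC(c1ccccc1)c1ccccn1` holds the highest of the two numbers in a functional assay on ileum for antagonist activity at histamine H1 receptor (Cavia porcellus) (on this read-out lower numbers stand for tighter binding and higher numbers for weaker binding), giving 11200 nM, whereas compound 1 `N=C(NCCCc1c[nH]cn1)NC(=O)CC(c1ccccc1)c1ccccc1` gives 741 nM. Within the data shown here, the single step between them, a 15-fold higher number from compound 1 to compound 2 (1.18 log units; beyond the scatter), shows how strongly this position responds. Compound 3 `N=C(NCCCc1c[nH]cn1)NC(=O)CC(c1ccccc1)c1nccs1` alters the same position again: 1,3-thiazol-2-yl in place of pyridin-2-yl on a saturated chain carbon bound to an aromatic carbon and a saturated chain carbon. Among the measured compounds shown here, no measured step exchanges pyridin-2-yl for 1,3-thiazol-2-yl, so the direction rests on that one step, a 15-fold higher number from compound 1 to compound 2 (1.18 log units; beyond the scatter), which argues only for a sizeable move either way. A moderate drop toward compound 1, a 2.2-fold lower number from compound 2 to compound 3 (0.35 log units; beyond the scatter), is expected. Compound 3 is estimated at 5000 nM in this assay, between 1000 nM and 25000 nM.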

Compound 3, dissociation constant: 4680 nM
For compound 3 the middle estimate is 1.1-fold (0.03 log units) above the measured one; measured number inside the range.
By their numbers in this assay, from the lowest: compound 1; then compound 3; then compound 2.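

In this assay, 1,3-thiazol-2-yl recovers only part of the loss seen with pyridin-2-yl (a 2.4-fold lower number from compound 2 to compound 3 (0.38 log units; beyond the scatter)), and it still does not match phenyl (a 6.3-fold higher number from compound 1 to compound 3 (0.80 log units; beyond the scatter)). The position therefore separates the two hetero aromatic rings from each other, while phenyl remains the best of the three groups in this assay. Nothing available accounts for the order of these three groups.

Going by these compounds, it remains open where a pyridin-3-yl or a cyclohexyl group on the same carbon would fall. The compounds also leave open whether any replacement can match phenyl here.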